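This account rests on a few compounds, and the source may have more. Where it says the series, first, only, none or still open, it means among the compounds named here.

Measured so far in a functional assay on the whole organism with Rattus norvegicus as the target; on this read-out lower numbers stand for an effect already at smaller amounts and higher numbers for an effect only at larger amounts of compound:
Compound 1 `CS(=O)(=O)c1ccc(-c2[nH]ccc2-c2ccc(F)cc2)cc1`: > 317 uM
Compound 2 `CS(=O)(=O)c1ccc(-c2[nH]c(I)c(I)c2-c2ccc(F)cc2)cc1`: 72.8 uM

Compound 1 has no exact number, only a limit of the assay: > 317 uM. Compound 3 `CS(=O)(=O)c1ccc(-c2[nH]c(C(=O)C(F)(F)F)cc2-c2ccc(F)cc2)cc1` keeps the core of compound 1, with (trifluoromethyl)carbonyl in place of hydrogen on an aromatic carbon next to the ring nitrogen ((trifluoromethyl)carbonyl in place of hydrogen on an aromatic carbon). Going by the values given here, no measured step shows what such a change does. Among the compounds with values here, the only guide is compound 2, which carries added groups on the core and gives 72.8 uM. The expected step of an at least 4.5-fold lower number from compound 1 to compound 3 (0.65 log units; beyond the scatter) therefore points toward lower numbers, with much uncertainty. For compound 3 the estimate is 70 uM, with an expected range from 15 uM to 300 uM.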

Compound 3, concentration for half-maximal effect: 47.2 uM
The estimate for compound 3 lay 1.5-fold (0.17 log units) above the measured number; low and high end bracket the measured number.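

In this assay one change alone, (trifluoromethyl)carbonyl in place of hydrogen on an aromatic carbon next to the ring nitrogen, gives an at least 6.7-fold lower number from compound 1 to compound 3 (0.82 log units; beyond the scatter) and so shows that this position can tolerate a group and that the change lowers the number. Compound 1 has only a limit of the assay, so this step has no upper end: the limit of > 317 uM in this assay, at which 1 of the 3 values shown sits.

As far as these compounds go, it remains open whether the trifluoromethyl part or the carbonyl matters more. From the compounds shown here alone, how an acetyl group, an amine or a carboxylic acid would behave at this position also remains open.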